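Carbonyl Linker Replacing Biaryl Bond in Acyltransferase Series

This account rests on a few compounds, and the source may have more. Where it says the series, first, only, none or still open, it means among the compounds named here.

Compound 1 `CCCCCCCCS(=O)(=O)Nc1cc(-c2ccc(Cl)cc2)ccc1C(=O)O` gives 18100 nM in an assay on mitochondria (strain BALB/c) for inhibition of glycerol-3-phosphate acyltransferase 1, mitochondrial (Mus musculus), read by scintillation counting, with a stated time of 10 min; on this read-out higher numbers stand for weaker inhibition and lower numbers for stronger inhibition.
Compound 2 `CCCCCCCCS(=O)(=O)Nc1ccc(-c2ccc(-c3ccccc3)cc2)cc1C(=O)O` gives 29100 nM in this assay.
Compound 3 `CCCCCCCCS(=O)(=O)Nc1ccc(-c2ccc(OC)cc2)cc1C(=O)O` gives 19500 nM in this assay.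

The three measured compounds differ only in the aryl group attached to the shared core. Compound 3 holds the second highest of the three numbers, yet its neighbours lie within the scatter on both sides: compound 1 sits a little lower and compound 2 a little higher. Within the data shown here, the one step between single-point neighbours, a 1.5-fold lower number from compound 2 to compound 3 (0.17 log units; within the scatter), stays within the scatter.

Compound 4 `CCCCCCCCS(=O)(=O)Nc1ccc(C(=O)c2ccccc2OC)cc1C(=O)O` is not yet measured. It differs from compound 3 by (2-methoxyphenyl)carbonyl in place of 4-methoxyphenyl on an aromatic carbon. Among the measured compounds shown here, no measured step exchanges a directly bound ring for a carbonyl-linked ring; the only step available concerns a substituent on the outer ring and was flat. The account therefore expects no step beyond the scatter from compound 3 to compound 4, a 1.0-fold higher number from compound 3 to compound 4 (0.01 log units; within the scatter). Compound 4 is estimated at 20000 nM, with a range from 8000 nM to 50000 nM.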

Compound 4, half-maximal inhibitory concentration: 59200 nM
For compound 4 the middle estimate is 3.0-fold (0.47 log units) below the measured one; the whole stated range lies below it.
By their numbers in this assay, from the lowest: compounds 1, 3 and 2 (each within the scatter of the next); then compound 4.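

In this assay, the aryl exchange at this place had stayed within the scatter in the step from compound 2 to compound 3, whereas the (2-methoxyphenyl)carbonyl group in place of 4-methoxyphenyl gives a 3.0-fold higher number from compound 3 to compound 4 (0.48 log units; beyond the scatter) and so moves the number modestly toward weaker inhibition. This position, meta to the carboxy group, therefore does respond to the group it carries, although this single step changes two things at once: a carbonyl enters as the link to the outer ring, and the methoxy group stands at a different place on that ring. Nothing available here explains the step.

The compounds shown leave open which of those two changes carries the step, as (4-methoxyphenyl)carbonyl would separate them. They also leave open how a methylene or an amine as the link would compare with the carbonyl.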